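The compounds below may be only part of what the source reports. "The series", "measured", "known", "first", "only" and "open" are said of these compounds alone.

Working notes on the series, read in a functional assay on MOLT-4 cells (Homo sapiens) for antiproliferative activity, with a stated time of 48 h; on this read-out lower numbers stand for stronger inhibition and higher numbers for weaker inhibition. Compound 1 (`C=C(Br)C(=O)Nc1ccc(/C=C/C(=O)c2ccc(Cl)cc2)cc1`) gives 810 nM, compound 2 (`Nc1ccc(/C=C/C(=O)c2ccc(Cl)cc2)cc1`) gives 7800 nM and compound 3 (`Nc1ccc(/C=C/C(=O)c2ccc(Cl)c(Cl)c2)cc1`) gives 13000 nM. Compound 2 thus stands level with compound 3 and clearly above compound 1. Compound 4 (`COc1ccc(C(=O)/C=C/c2ccc(N)cc2)cc1`) differs from compound 2 by methoxy in place of chloro on an aromatic carbon. The nearest measured change, a 1.7-fold higher number from compound 2 to compound 3 (0.22 log units; within the scatter), also falls on an aromatic carbon and stays within the scatter. The larger step, a 9.6-fold higher number from compound 1 to compound 2 (0.98 log units; beyond the scatter), concerns the nitrogen and does not bear on this change. Among the measured compounds shown here, no measured compound carries methoxy, so no step beyond the scatter is expected in this assay. The expected step is a 1.2-fold higher number from compound 2 to compound 4 (0.06 log units; within the scatter). For compound 4 the estimated value is 9000 nM, with an expected range of 3000 nM to 25000 nM.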

Compound 4, half-maximal inhibitory concentration: 19000 nM
Beside the measured number, compound 4's estimate is 2.1-fold (0.32 log units) below it, within the range that was stated.
By their numbers in this assay, from the lowest: compound 1; then compounds 2, 3 and 4 (each within the scatter of the next, the first and the last beyond it).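

Methoxy in place of chloro on this aromatic carbon, para to a large group, gives a 2.4-fold higher number from compound 2 to compound 4 (0.39 log units; beyond the scatter) and so moves toward weaker inhibition. Among the compounds shown here, this is the first change on the aromatic carbons of this series to go beyond the scatter, as the added chloro gave only a 1.7-fold higher number from compound 2 to compound 3 (0.22 log units; within the scatter). No evidence on the cause of this step is at hand.

The compounds shown leave open how an amine or a carboxylic acid on this carbon would read. Going by these compounds, it also remains open whether the same change holds with the (1-bromoethenyl)carbonyl of compound 1 on the nitrogen.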